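The source may report more compounds than this note shows. Statements on the series, on what has been measured and on what is new or still open speak of the compounds shown alone.

Series notes. Compound 2 `COc1ccc(F)c(-c2ccc3c(NC(=O)c4ccc(N5CCN(C(C)=O)CC5)cc4)n[nH]c3c2)c1F` stands alongside compound 1 `COc1ccc(F)c(-c2ccc3c(NC(=O)c4ccc(N(C)CCN(C)C)cc4)n[nH]c3c2)c1F` in a functional assay on SNU-16 cells (Homo sapiens) for antiproliferative activity, read by CCK-8 assay, with a stated time of 72 h; a higher number here means a weaker inhibitor, a lower number a stronger inhibitor; compound 2 gives 322 nM and compound 1 gives 366 nM, and the two values lie within the scatter of each other, so neither can be ranked against the other. Among the compounds with values here, the one measured step, a 1.1-fold lower number from compound 1 to compound 2 (0.06 log units; within the scatter), exchanged the whole amine substituent on the aromatic carbon and moved nothing beyond the scatter. Compound 3 `CCN1CCN(c2ccc(C(=O)Nc3n[nH]c4cc(-c5c(F)ccc(OC)c5F)ccc34)cc2)CC1` differs from compound 2 by ethyl in place of acetyl on an amine nitrogen in a ring. Within the data shown here, no measured pair changes the group on that ring nitrogen, so the step from compound 1 to compound 2 bears only loosely, as an indication that changes in this part of the molecule have so far stayed within the scatter. Compound 3 is therefore expected to show a step of a 1.2-fold lower number from compound 2 to compound 3 (0.09 log units; within the scatter) in this assay, no larger than the scatter. The estimate for compound 3 is 260 nM, with a range from 100 nM to 700 nM.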

Compound 3, half-maximal inhibitory concentration: 77.4 nM
Compound 3: middle estimate off by 3.4-fold (0.53 log units), on the high side; measured number outside the range, below it.
By their numbers in this assay, from the lowest: compound 3; then compounds 2 and 1 (each within the scatter of the next).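

In this assay, within the data shown here, the exchange of acetyl for ethyl on the amine nitrogen in the ring gives a 4.2-fold lower number from compound 2 to compound 3 (0.62 log units; beyond the scatter) and is the first step beyond the scatter, so the group on this nitrogen matters in a way the earlier exchange of the whole amine substituent did not show. The 4-ethylpiperazin-1-yl group also separates from the open-chain amine of compound 1, with a 4.7-fold lower number from compound 1 to compound 3 (0.67 log units; beyond the scatter), while the 4-acetylpiperazin-1-yl group of compound 2 does not, so the piperazine ring alone does not set the value. Nothing available gives a reason for this step.

On these data alone, whether the step belongs to ethyl itself remains open. A methyl, an isopropyl, a longer chain or a plain hydrogen on that nitrogen would show how far it extends.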